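The compounds below may be only part of what the source reports. "The series", "measured", "known", "first", "only" and "open" are said of these compounds alone.

Values in a functional assay on HT-29 cells (Homo sapiens) for inhibition, read by MTT assay, with a stated time of 72 h; on this read-out lower numbers stand for stronger inhibition of growth and higher numbers for weaker inhibition of growth:
compound 1 `COc1ccc(CNC(=O)/C(C#N)=C/c2cc(Br)co2)cc1`: 36000 nM
compound 2 `COc1ccc(CNC(=O)/C(C#N)=C/c2ccc3ccccc3c2)cc1`: 54000 nM
compound 3 `COc1ccc(CNC(=O)/C(C#N)=C/c2cccc3ccccc23)cc1`: 13000 nM

Compound 3 carries the lowest number of the three. Its nearest neighbour is compound 1, whose value lies higher by a margin beyond the scatter, and compound 2 lies further away still, also beyond the scatter. Compound 3 is therefore the strongest of the three on this read-out.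

Compound 4 `N#C/C(=C\c1cccc2ccccc12)C(=O)NCc1ccc(Cl)c(Cl)c1` keeps the core of compound 3 and differs from it in one place: 3,4-dichlorophenyl in place of 4-methoxyphenyl on a saturated chain carbon bound to an amide-type nitrogen. Among the compounds with values here, no measured pair shows this exchange, so there is no step from which its size can be read. The three measured compounds vary only in the group attached to the shared core, and all of them carry the 4-methoxyphenyl part that is replaced here. With nothing to anchor the step, the expectation is a change that stays near the scatter, if anything a small move toward a lower number; the estimated step is a 1.3-fold lower number from compound 3 to compound 4 (0.11 log units; within the scatter). Compound 4 is accordingly expected to give 10000 nM in this assay, within a range from 3000 nM to 40000 nM.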

Compound 4, concentration for 50% growth inhibition: 7000 nM
For compound 4 the middle estimate is 1.4-fold (0.15 log units) above the measured one, and the stated range covers the measured number.
By their numbers in this assay, from the lowest: compounds 4 and 3 (each within the scatter of the next); then compounds 1 and 2 (each within the scatter of the next).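

In this assay the exchange at this position, 3,4-dichlorophenyl in place of 4-methoxyphenyl on a saturated chain carbon bound to an amide-type nitrogen, amounts to a 1.9-fold lower number from compound 3 to compound 4 (0.27 log units; within the scatter), so the two compounds stand level. Within the data shown here, the earlier compounds all carried 4-methoxyphenyl and varied only in the group at the other end of the shared core, so this is the first reading at this position: for this one pair, the oxygen of 4-methoxyphenyl is not needed to keep the level of growth inhibition, and a ring carrying chlorine serves equally well. Nothing at hand speaks to the reason for this result.

As far as these compounds go, whether the same exchange stays as small with the groups that compound 1 and compound 2 carry on the shared core remains open, since the exchange is seen on the core of compound 3 alone. Also open, from the compounds shown here alone, is how far this position tolerates other kinds of group, such as an unsubstituted phenyl, a single chlorine on the ring, a longer chain to the ring, or a ring bearing an amine or a carboxylic acid.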